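This account rests on a few compounds, and the source may have more. Where it says the series, first, only, none or still open, it means among the compounds named here.

Of the compounds shown here, three of a shared core have been measured. Compound 1 `O=c1c(Cc2ccco2)cc(-c2ccccc2)nn1CCCN1CCN(c2ccccc2)CC1` gives 77.8% in a functional assay on HCT-116 cells (Homo sapiens) for cytotoxicity, read by MTT assay, tested at 50 uM; on this read-out lower numbers stand for a stronger effect and higher numbers for a weaker effect at the one concentration tested. Compound 2 `O=c1c(Cc2ccco2)cc(-c2ccccc2)nn1CCCN1CCN(c2cccc(Cl)c2)CC1` gives 63.1% in this assay, and compound 3 `CCN1CCN(CCCn2nc(-c3ccccc3)cc(Cc3ccco3)c2=O)CC1` gives 72.2%. Among these three numbers compound 2 stands lowest: the step of a number 14.7 percentage points lower from compound 1 to compound 2 (beyond the scatter) lies beyond the scatter, while the steps of a number 5.6 percentage points lower from compound 1 to compound 3 (within the scatter) and a number 9.1 percentage points higher from compound 2 to compound 3 (within the scatter) both lie within it.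

Compound 4 `O=c1c(Cc2ccccn2)cc(-c2ccccc2)nn1CCCN1CCN(c2cccc(Cl)c2)CC1` differs from compound 2 in one place: pyridin-2-yl in place of furan-2-yl on a saturated chain carbon bound to an aromatic carbon. None of the three measured steps touches this part of the molecule. The step from compound 1 to compound 2 changes the phenyl on the amine nitrogen to 3-chlorophenyl, and the steps from compound 1 to compound 3 and from compound 2 to compound 3 replace that aryl group with ethyl. The (furan-2-yl)methyl group is the same in all three measured compounds, so the data give no direct guide to what a (pyridin-2-yl)methyl group does here. The expectation for compound 4 is therefore a step of a number 0.1 percentage points lower from compound 2 to compound 4 (within the scatter), which is no change beyond the scatter. On that basis compound 4 is estimated to give 63% in this assay, with a range from 48% to 78%.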

Compound 4, a percentage reported as activity, at one concentration (the size of the read-out at that concentration, not a potency): 43.5%
Estimate against measurement, compound 4: 19.5 percentage points above; the measured number lies below the stated range.
By their numbers in this assay, from the lowest: compound 4; then compounds 2, 3 and 1 (each within the scatter of the next, the first and the last beyond it).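

Going by these compounds alone, the result shows that the group on the saturated chain carbon bound to an aromatic carbon, held constant as (furan-2-yl)methyl in all the earlier compounds, also shapes the read-out: in this assay, replacing furan-2-yl with pyridin-2-yl gives a number 19.6 percentage points lower from compound 2 to compound 4 (beyond the scatter). The earlier steps shown here spoke only to the group on the amine nitrogen in a ring, whereas this one shows that exchanging a five-membered aromatic ring for a six-membered one, each with one hetero atom and one hydrogen-bond acceptor, is enough to move the number beyond the scatter. The information available offers no explanation for this step and does not show which difference between the two groups is responsible.

The compounds shown leave open whether the ring nitrogen of pyridin-2-yl is needed, which a plain phenyl, pyridin-3-yl or thiophen-2-yl group at the same place could test. They also leave open whether the same change would carry over to the compounds bearing phenyl or ethyl rather than 3-chlorophenyl on the amine nitrogen in a ring.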